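This account rests on a few compounds, and the source may have more. Where it says the series, first, only, none or still open, it means among the compounds named here.

Three compounds that share one core were tested in a functional assay on the whole organism with Rattus norvegicus as the target, read by paw edema, with a stated time of 3 h, at a dose of 100 mg/kg by the oral route; on this read-out lower numbers stand for less inhibition and higher numbers for more inhibition at the one dose given (going by the name of the read-out). Compound 1 `Cc1cccc(-c2nc3cc(Cl)ccc3[nH]2)n1` gives 39%. Compound 2 `CCc1ccc(-c2nc3cc(O)ccc3[nH]2)nc1` gives 25% in this assay. Compound 3 `CCc1ccc(-c2nc3cc([N+](=O)[O-])ccc3[nH]2)nc1` gives -5% in this assay, the lowest of the three numbers; compound 2 stands nearest to it and compound 1 furthest from it, both beyond the scatter. Among the measured compounds shown here, the one measured step that bears on the next change is a number 30 percentage points lower from compound 2 to compound 3 (beyond the scatter), a modest drop beyond the scatter.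

Compound 4 `CCc1ccc(-c2nc3cc(NC(C)=O)ccc3[nH]2)nc1` differs from compound 3 by acetamido in place of nitro on an aromatic carbon. The entering acetamido brings one hydrogen-bond donor and one acceptor where the nitro carried two acceptors and no donor. Because a number 30 percentage points lower from compound 2 to compound 3 (beyond the scatter) fell beyond the scatter when the nitro entered, removing the nitro is expected to recover much of that loss. The step from compound 3 to compound 4 is estimated as a rise of a number 25 percentage points higher from compound 3 to compound 4 (beyond the scatter). Compound 4 is therefore expected to give about 20% in this assay, within a range from 0% to 40%.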

Compound 4, a percentage reported as inhibition, in the whole organism at one dose (the size of the read-out at that dose, not a potency): 5%
Compound 4: middle estimate off by 15 percentage points, on the high side; the measured number falls inside the stated range.
By their numbers in this assay, from the lowest: compounds 3 and 4 (each within the scatter of the next); then compound 2; then compound 1.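

On an aromatic carbon of the shared core, acetamido in place of nitro gives, in this assay, a number 10 percentage points higher from compound 3 to compound 4 (within the scatter) and so does not separate these two groups on this read-out, even though acetamido carries a hydrogen-bond donor and nitro carries none. Set against hydroxy at the same place, acetamido gives a number 20 percentage points lower from compound 2 to compound 4 (beyond the scatter) and thus does not match the hydroxy compound, so having a hydrogen-bond donor there does not alone bring back the number seen with hydroxy. No measured evidence here accounts for either step.

The compounds shown leave open how a free amine or a carboxylic acid would read at this place, and whether a longer chain on the amide would shift the number. Compound 1 differs from the others in more than one place, so its chloro cannot be compared directly with these groups.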